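From Isopropylsulfanyl to Dimethylamino on a Carbonyl Carbon

The source may hold more compounds than are shown below. What is called first, only, known or untested is meant among the compounds shown, and "the series" means these compounds.

Of the compounds shown here, two with a shared core have been measured so far in a physicochemical assay for lipophilicity; a higher number here means a more lipophilic compound, a lower number a more polar compound. Compound 1 `CC(/C=C/CC(C)CCCC(C)C)=C\C(=O)OC(C)(C)C` gives 7.56, and compound 2 `CC(/C=C/CC(C)CCCC(C)C)=C\C(=O)SC(C)C` gives 8.39, the higher of the two numbers. Among the measured compounds shown here, compound 3 `CC(/C=C/CC(C)CCCC(C)C)=C\C(=O)N(C)C` has no measurement yet. It has dimethylamino in place of isopropylsulfanyl on a carbonyl carbon.

For the measured compounds named here, only one measured step bears on this change. Putting isopropylsulfanyl in place of tert-butoxy on a carbonyl carbon gave a number 0.83 log units higher from compound 1 to compound 2 (beyond the scatter), a modest step but one beyond the scatter. It shows that the group on this carbon can move the number. Going by the values given here, compound 3 gives up the isopropylsulfanyl group of compound 2, which holds the top value so far. Among the compounds with values here, no measured compound carries dimethylamino, so the size of the step remains a judgement. Within the data shown here, a fall somewhat larger than the one measured step is expected in this assay, an estimated a number 1.89 log units lower from compound 2 to compound 3 (beyond the scatter). The expected value for compound 3 is 6.5, within an estimated range of 5.7 to 7.3.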

Compound 3, partition coefficient: 4.94
The estimate for compound 3 lay 1.56 log units above the measured number; measured number outside the range, below it.
By their numbers in this assay, from the lowest: compound 3; then compound 1; then compound 2.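

In this assay, among the compounds shown here, dimethylamino in place of isopropylsulfanyl gives a number 3.45 log units lower from compound 2 to compound 3 (beyond the scatter) while dimethylamino in place of tert-butoxy gives a number 2.62 log units lower from compound 1 to compound 3 (beyond the scatter) and both of these steps count as large, where the one earlier step on this carbonyl carbon was modest. Compound 3 therefore sits lowest of the three, beyond the scatter from each of the others, so a change at this one place, with the shared core untouched, spans a much wider range of numbers than compound 1 and compound 2 alone revealed. No measurement available here accounts for the size of this drop.

The three compounds cannot tell whether the low number belongs to dimethylamino alone or would also appear with other nitrogen groups on this carbonyl carbon, such as a plain amino group, a methylamino group or a pyrrolidine ring. They also leave open where a methoxy group or a carboxylic acid at the same place would fall, and whether the same exchange would give a step of similar size on a shorter chain.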